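A ring carbonyl added to compound 3

The compounds below may be only part of what the source reports. "The series", "measured", "known", "first", "only" and "open" are said of these compounds alone.

In an ADME assay on a cell-free system (plasma, Mus musculus) for metabolic stability, read by LC-MS, tested at 2 uM (a higher number here means that the compound lasts longer, a lower number that the compound disappears faster), compound 3 `CN1CCN(c2ccc3c(c2)oc(=O)n3C(=O)NCCCCc2ccccc2)CC1` gives < 0.0834 h, which is a limit of the assay and not a number. Two close relatives give real numbers: compound 2 `CN1CCN(c2ccc3c(c2)oc(=O)n3C(=O)NCCCCc2ccccc2)C(=O)C1` shows a half-life of 0.333 h, and compound 1 `CN1CCC(c2ccc3c(c2)oc(=O)n3C(=O)NCCCCc2ccccc2)CC1=O` shows 0.6 h.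

Compound 4 `CN1CCN(c2ccc3c(c2)oc(=O)n3C(=O)NCCCCc2ccccc2)CC1=O` has not been measured yet. It carries 4-methyl-3-oxopiperazin-1-yl in place of the 4-methylpiperazin-1-yl of compound 3, on an aromatic carbon of the shared core: 4-methyl-3-oxopiperazin-1-yl in place of 4-methylpiperazin-1-yl on an aromatic carbon.

Among the measured compounds shown here, the most relevant measured step is an at least 3.9-fold lower number from compound 2 to compound 3 (0.60 log units; beyond the scatter), where 4-methylpiperazin-1-yl replaces 4-methyl-2-oxopiperazin-1-yl, a group whose name differs from the one in compound 4 only in the number of the oxo position. The step of an at least 7.1-fold lower number from compound 1 to compound 3 (0.85 log units; beyond the scatter) points the same way. The two measured groups with an oxo stay within the scatter of each other, as a 1.8-fold lower number from compound 1 to compound 2 (0.26 log units; within the scatter) shows.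

Compound 4 is therefore expected to resemble compound 2 and compound 1 more than its direct parent, and the expected step is an at least 3.9-fold higher number from compound 3 to compound 4 (0.59 log units; beyond the scatter). For compound 4 the estimated half-life is 0.33 h, with an expected range of 0.15 h to 0.7 h.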

Compound 4, half-life: 0.333 h
Estimate against measurement, compound 4: 1.0-fold (0.00 log units) below; measured number inside the range.
By their numbers in this assay, from the lowest: compounds 2, 4 and 1 (each within the scatter of the next). At a limit, below all of these: compound 3.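

In this assay the change from 4-methylpiperazin-1-yl to 4-methyl-3-oxopiperazin-1-yl gives an at least 3.9-fold higher number from compound 3 to compound 4 (0.60 log units; beyond the scatter) and shows that a second oxo position on this ring also goes with a longer half-life than the plain ring. The exact oxo position makes no readable difference among the groups compared here, with no change at the digits printed from compound 2 to compound 4 (within the scatter) for 4-methyl-2-oxopiperazin-1-yl and a 1.8-fold lower number from compound 1 to compound 4 (0.26 log units; within the scatter) for 1-methyl-2-oxopiperidin-4-yl, so all three groups with an oxo sit together and none of the four compounds goes against this. From the compounds shown here alone, compound 3 stands at a limit of the assay and not at a number, so the full size of the step from it stays unknown: the limit of < 0.0834 h in this assay, at which 1 of the 4 values shown sits.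

The compounds shown leave open whether a carbonyl must be part of the ring at all, as 4-acetylpiperazin-1-yl, with its carbonyl outside the ring, or a morpholine on the same aromatic carbon could test. They also leave open whether the same change holds when the phenylbutyl chain on the shared core is replaced by a shorter chain.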